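From Hydroxymethyl to Carboxy on the Shared Core

The compounds below may be only part of what the source reports. "The series", "measured", "known", "first", "only" and "open" are said of these compounds alone.

Within the data shown here, in a physicochemical assay for solubility, read by HPLC, at pH 7.4 (a higher number here means a more soluble compound, a lower number a less soluble compound), compound 2 (`CCCCCCCc1[nH]c2ccccc2c(=O)c1CO`) reads 50000 nM, the highest of the three numbers so far. Compound 1 (`CCCCCCCc1cc(OC)c2ccccc2n1`) gives 5000 nM, and compound 3 (`CCCCCCCc1[nH]c2ccc([N+](=O)[O-])cc2c(=O)c1CO`) gives 5000 nM, so both sit below compound 2 by a margin beyond the scatter.

Compound 4 (`CCCCCCCc1[nH]c2ccccc2c(=O)c1C(=O)O`) has not yet been measured. It carries carboxy in place of hydroxymethyl on an aromatic carbon, two atoms from the ring nitrogen: carboxy in place of hydroxymethyl on an aromatic carbon.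

Among the measured compounds shown here, only one measured step starts from compound 2: a 10-fold lower number from compound 2 to compound 3 (1.00 log units; beyond the scatter), a modest change with nitro in place of hydrogen on an aromatic carbon. That step involves different groups on a different carbon, so it offers a gauge of size but no direction. For the measured compounds named here, no measured pair exchanges hydroxymethyl for carboxy. Going by the values given here, the central expectation in this assay is therefore no step beyond the scatter, with the direction left open and any real shift expected to be smaller than the one to compound 3. The estimated change is a 1.2-fold higher number from compound 2 to compound 4 (0.08 log units; within the scatter). For compound 4 the estimated value is 60000 nM, with an expected range from 15000 nM to 200000 nM.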

Compound 4, solubility: 15000 nM
Compound 4: the middle estimate sits 4.0-fold (0.60 log units) above what was measured; the range from low to high includes it.
By their numbers in this assay, from the lowest: compounds 1 and 3 (each within the scatter of the next); then compound 4; then compound 2.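

At the aromatic carbon two atoms from the ring nitrogen, the exchange of hydroxymethyl for carboxy does register in this assay: the result is a 3.3-fold lower number from compound 2 to compound 4 (0.52 log units; beyond the scatter) and that step lies beyond the scatter. Among these compounds, this is the first reading at this place on the shared core, and it shows that a change there, one that adds a heavy atom and a double bond outside the aromatic rings while the counts of hydrogen-bond donors and acceptors stay the same and no net charge appears, goes the same way as a 10-fold lower number from compound 2 to compound 3 (1.00 log units; beyond the scatter) but by a smaller step. No measurement offered here explains the step or ties it to any feature of either group.

What the compounds shown leave open is how other groups at this place, such as an amine, a methyl ester or a primary amide, would read against compound 2. As far as these compounds go, it also remains open whether the exchange would give a similar step with nitro on the shared core, or with a shorter chain in place of the group of 7 heavy atoms.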